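The compounds below may be only part of what the source reports. "The series", "measured", "known", "first", "only" and "open" are said of these compounds alone.

Series overview, cytotoxicity on breast-derived cells:

- compound 1, `COc1ccc(N/C(CCNC2=CC(=O)c3ccccc3C2=O)=N\S(=O)(=O)c2ccc(C)cc2)cc1`: 6030 nM
- compound 2, `COc1ccc(N/C(CCNC2=CC(=O)c3ccccc3C2=O)=N\S(=O)(=O)c2ccc(C)cc2)cc1OC`: 12300 nM
- compound 3, `COc1ccc(N/C(CCNC2=CC(=O)c3ccccc3C2=O)=N\S(=O)(=O)c2ccc(C(C)(C)C)cc2)cc1OC`: 8710 nM

In a functional assay on MCF7 cells (Homo sapiens) for cytotoxicity, read by MTT assay, with a stated time of 48 h (on this read-out lower numbers stand for stronger inhibition and higher numbers for weaker inhibition), compound 2 gives the highest of the three numbers. Its nearest neighbour is compound 3, reached by a 1.4-fold lower number from compound 2 to compound 3 (0.15 log units; within the scatter), a difference within the scatter. The larger gap is to compound 1, described by a 2.0-fold higher number from compound 1 to compound 2 (0.31 log units; beyond the scatter), which lies just beyond the scatter.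

Compound 4, `Cc1ccc(S(=O)(=O)/N=C(\N)CCNC2=CC(=O)c3ccccc3C2=O)cc1`, is not yet measured. Relative to compound 2 the change is hydrogen in place of 3,4-dimethoxyphenyl on an amine nitrogen.

For the measured compounds named here, only one measured step touches this part of the molecule: a 2.0-fold higher number from compound 1 to compound 2 (0.31 log units; beyond the scatter), where adding a methoxy to the aryl group attached to the amine nitrogen raised the number modestly. Going by the values given here, no measured step removes the aryl group altogether, so the bearing of that step on compound 4 is indirect. Taking the aryl group away also takes away the methoxy whose addition raised the number in compound 2, which argues for a number somewhat lower than that of compound 2, though the remainder of the change is uncharted.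

The expectation for compound 4 is therefore a modest lowering, a 1.8-fold lower number from compound 2 to compound 4 (0.24 log units; within the scatter), roughly back toward the level of compound 1. Compound 4 is estimated at 7000 nM, with a range of 2500 nM to 20000 nM.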

Compound 4, half-maximal inhibitory concentration: 18600 nM
Beside the measured number, compound 4's estimate is 2.7-fold (0.42 log units) below it, within the range that was stated.
By their numbers in this assay, from the lowest: compounds 1, 3, 2 and 4 (each within the scatter of the next, the first and the last beyond it).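

In this assay, taking the whole 3,4-dimethoxyphenyl group off the amine nitrogen and leaving hydrogen gives a 1.5-fold higher number from compound 2 to compound 4 (0.18 log units; within the scatter), so at this position the hydrogen compound cannot be told apart from the dimethoxy compound. Set against the 4-methoxyphenyl group, the same kind of change gives a 3.1-fold higher number from compound 1 to compound 4 (0.49 log units; beyond the scatter), so the outcome of removing the aryl group depends on which aryl group leaves: of the two, only 4-methoxyphenyl is separated from hydrogen beyond the scatter. Nothing available explains this difference between the two aryl groups.

Still open, going by these compounds, is what a phenyl group without methoxy, a benzyl group or a short alkyl chain on this amine nitrogen would give, which would show whether the number follows the methoxy groups or the presence of an aryl ring at all. Also open, on these data alone, is whether the step from methyl to tert-butyl on the other aromatic ring, a 1.4-fold lower number from compound 2 to compound 3 (0.15 log units; within the scatter), carries over to compounds with hydrogen on this nitrogen.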